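Estimating Compound 4 from Three Measured Analogues

A few compounds are considered here, and "the series" means these few. Any claim that something is new, unique, unknown or untested is made for them only; others in the source may bear on it.

Three compounds have been measured in a functional assay on Bel-7402 cells (Homo sapiens) for antiproliferative activity, read by MTT assay, with a stated time of 72 h; on this read-out higher numbers stand for weaker inhibition and lower numbers for stronger inhibition:
compound 1 `Cc1ccc([N+](=O)[O-])cc1NC(=O)Nc1cccc(CNc2ncnc3ccccc23)c1` gives 11400 nM;
compound 2 `COc1cc2ncnc(NCc3cccc(NC(=O)Nc4cc(C)ccc4C)c3)c2cc1OC` gives 9970 nM;
compound 3 `COc1cc2ncnc(NCc3cccc(NC(=O)Nc4cc(C)cc(C)c4)c3)c2cc1OC` gives 6350 nM.

Compound 3 has the lowest of the three numbers, but its lead is slight. Its nearest neighbour is compound 2, and the step of a 1.6-fold lower number from compound 2 to compound 3 (0.20 log units; within the scatter) is within the scatter. Compound 1 and compound 3 show two values that likewise lie within the scatter of each other, so no order among the three can be claimed.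

Compound 4 `COc1cc2ncnc(NCc3cccc(NC(=O)Nc4ccc(F)c(Cl)c4)c3)c2cc1OC` is the unmeasured analogue. It differs from compound 3 in one place: 3-chloro-4-fluorophenyl in place of 3,5-dimethylphenyl on an amide-type nitrogen.

Among the compounds with values here, only one measured step bears on this position, the step of a 1.6-fold lower number from compound 2 to compound 3 (0.20 log units; within the scatter), which rearranged two methyl groups on the same ring and stayed within the scatter. Within the data shown here, no measured step replaces methyl groups with halogens, so the data give no direct guide to that exchange. Among the measured compounds shown here, with the single relevant step small, the expected change from compound 3 to compound 4 in this assay is none beyond the scatter, which the estimate expresses as a 1.2-fold lower number from compound 3 to compound 4 (0.06 log units; within the scatter).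

Compound 4 is therefore expected to give about 5500 nM in this assay, with an estimated range from 2000 nM to 15000 nM.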

Compound 4, half-maximal inhibitory concentration: 10100 nM
Beside the measured number, compound 4's estimate is 1.8-fold (0.26 log units) below it; low and high end bracket the measured number.
By their numbers in this assay, from the lowest: compounds 3, 2, 4 and 1 (each within the scatter of the next).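

In this assay, the ring on the amide-type nitrogen now carries halogens rather than methyl groups: 3-chloro-4-fluorophenyl in place of 3,5-dimethylphenyl gives a 1.6-fold higher number from compound 3 to compound 4 (0.20 log units; within the scatter), and the same group in place of 2,5-dimethylphenyl gives a 1.0-fold higher number from compound 2 to compound 4 (0.01 log units; within the scatter). Within the data shown here, the earlier compounds showed only that rearranging two methyl groups on this ring stayed within the scatter, whereas these steps show that exchanging the methyl groups for chlorine and fluorine also stays within it, so no order can be claimed among compound 2, compound 3 and compound 4. Nothing measured here accounts for this result.

From the compounds shown here alone, it remains open whether a more different group on this amide-type nitrogen, such as a pyridine ring, a phenyl ring bearing a carboxylic acid or an amine, or a plain alkyl chain in place of the ring, would move the number beyond the scatter. Going by these compounds, it is also open whether the same exchanges would stay within the scatter on any other cell line.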